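This account rests on a few compounds, and the source may have more. Where it says the series, first, only, none or still open, it means among the compounds named here.

Measured so far:
Compound 1 `CCN(Cc1ccc(C(=O)NO)cc1)c1ncc(-c2ccc(C)cc2)s1`: 2700 nM
Compound 2 `CCCCCCCCN(Cc1ccc(C(=O)NO)cc1)c1ncc(-c2ccc(C)cc2)s1`: 4630 nM

In a functional assay on A549 cells (Homo sapiens) for antiproliferative activity, read by MTT assay, with a stated time of 48 h (on this read-out lower numbers stand for stronger inhibition of growth and higher numbers for weaker inhibition of growth), compound 2 gives 4630 nM, level within the scatter with compound 1 at 2700 nM, so neither number stands apart from the other.

Compound 3 `Cc1ccc(OCCCN(Cc2ccc(C(=O)NO)cc2)c2ncc(-c3ccc(C)cc3)s2)cc1` keeps the shared core and differs from compound 2 in one place: 4-methylphenoxy in place of pentyl on a saturated chain carbon, three bonds along the chain from a nitrogen on an aromatic ring. The octyl chain thus gives way to 3-(4-methylphenoxy)propyl.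

Among the measured compounds shown here, only one measured step bears on this change: a 1.7-fold higher number from compound 1 to compound 2 (0.23 log units; within the scatter). That step put hexyl in place of hydrogen on the same chain, and it suggests, for these two compounds alone, that a longer group here need not move the number much. For the measured compounds named here, no measured compound carries a ring in this chain, so the guide is weak and the range has to stay wide. No step beyond the scatter is expected in this assay. The expected size is a 1.3-fold lower number from compound 2 to compound 3 (0.12 log units; within the scatter). Compound 3 is estimated at 3500 nM, with an expected range of 1300 nM to 9000 nM.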

Compound 3, concentration for 50% growth inhibition: 32500 nM
Compound 3: middle estimate off by 9.3-fold (0.97 log units), on the low side, and the stated range ends below it.
By their numbers in this assay, from the lowest: compounds 1 and 2 (each within the scatter of the next); then compound 3.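

In this assay, replacing the octyl chain with 3-(4-methylphenoxy)propyl gives a 7.0-fold higher number from compound 2 to compound 3 (0.85 log units; beyond the scatter) and so weakens growth inhibition beyond the scatter, which shows that this position does not treat all long groups alike. Set against the shared reference, the same group gives a 12-fold higher number from compound 1 to compound 3 (1.08 log units; beyond the scatter) while the octyl chain of compound 2 stays within the scatter of compound 1, so the earlier pair, which held no ring in this chain, gave no hint of a change this size. No measurement here explains the loss of activity.

The change brings in an oxygen, an aromatic ring and a methyl on that ring all at once, so these compounds cannot say which part matters: a 3-phenylpropyl chain, with no oxygen, or a 3-phenoxypropyl chain, with no methyl, would begin to pull them apart. Also open, on these data alone, is how this position responds to a chain carrying an amine or a carboxylic acid, since only neutral groups appear among the three compounds.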